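This account rests on a few compounds, and the source may have more. Where it says the series, first, only, none or still open, it means among the compounds named here.

Compound 1 `CC(C)(C)[Si](CCc1c(N2CCNCC2)nc2ccc(Cl)cc2c1-c1ccccc1Cl)(c1ccccc1)c1ccccc1` and compound 2 `CC(C)(C)[Si](CCc1c(Nn2nnc3ccccc32)nc2ccc(Cl)cc2c1-c1ccccc1Cl)(c1ccccc1)c1ccccc1` share one core, while compound 3 `OCCc1c(N2CCNCC2)nc2ccc(Cl)cc2c1-c1ccccc1Cl` and compound 4 `OCCc1c(Nn2nnc3ccccc32)nc2ccc(Cl)cc2c1-c1ccccc1Cl` share another; the difference between the two cores is not broken down here. In an ADME assay on HepG2 2.2.15 cells (Homo sapiens) for cytotoxicity (a higher number here means that more compound is tolerated, a lower number that less compound is tolerated), compound 1 gives only a limit of the assay, < 18800 nM. Compound 2 likewise gives only a limit in this assay, > 1250000 nM. The change between them is a group of 10 heavy atoms (6 carbon, 4 nitrogen; one five-membered aromatic ring with 3 hetero atoms, one six-membered aromatic ring of carbon only) in place of a group of 6 heavy atoms (4 carbon, 2 nitrogen; one six-membered non-aromatic ring with 2 hetero atoms), on an aromatic carbon, and it brings an at least 66-fold higher number from compound 1 to compound 2 (1.82 log units; beyond the scatter). That step rests on two limits, the limit of < 18800 nM in this assay, at which 1 of the 3 values shown sits, and (the limit of > 1250000 nM in this assay, at which 1 of the 3 values shown sits), so its true size is not pinned down. Compound 3 gives only a limit in this assay as well, < 5000 nM. From compound 3 to compound 4 the same kind of change is made, (a group of 10 heavy atoms (6 carbon, 4 nitrogen; one five-membered aromatic ring with 3 hetero atoms, one six-membered aromatic ring of carbon only) in place of a group of 6 heavy atoms (4 carbon, 2 nitrogen; one six-membered non-aromatic ring with 2 hetero atoms), on an aromatic carbon), though here the place is ortho to a 2-hydroxyethyl group rather than ortho to a large group. The expected step for compound 4 is an at least 100-fold higher number from compound 3 to compound 4 (2.00 log units; beyond the scatter), since a step of the same kind, an at least 66-fold higher number from compound 1 to compound 2 (1.82 log units; beyond the scatter), was seen and compound 3 starts from the limit of < 5000 nM in this assay, at which 1 of the 3 values shown sits. Compound 4 is therefore estimated at 500000 nM, between 50000 nM and 3000000 nM, with a good chance that this assay again reports only a limit.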

Compound 4, half-maximal cytotoxic concentration: 82400 nM
Beside the measured number, compound 4's estimate is 6.1-fold (0.78 log units) above it; the measured number falls inside the stated range.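

In this assay, putting the group with the five-membered aromatic ring in place of piperazin-1-yl gives an at least 16-fold higher number from compound 3 to compound 4 (1.21 log units; beyond the scatter). The same change also raised the number on the core of compound 1, so on these two cores it points the same way, and more compound is tolerated after the change on both. This shows that the direction carried over from one core to the other, but not that the size did, because each step starts from a limit rather than a true number: the same change on two cores in this assay, an at least 66-fold higher number (1.82 log units; beyond the scatter) from compound 1 to compound 2 and an at least 16-fold higher number (1.21 log units; beyond the scatter) from compound 3 to compound 4; the limit leaves it open whether they differ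

The compounds shown compare only these two groups at this place, so it stays open how a morpholine ring or a simple amine such as dimethylamino would behave there. As far as these compounds go, it also stays open whether the direction would hold on a core carrying a longer chain, such as 3-hydroxypropyl, in place of the 2-hydroxyethyl group.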